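Swapping an ortho ether for a methoxymethyl arm

The compounds below may be only part of what the source reports. "The series", "measured", "known", "first", "only" and "open" are said of these compounds alone.

Measured compounds in a functional assay on CHO cells for agonist activity at Alpha-1A adrenergic receptor (Homo sapiens), read by FLIPR and calcium flux; a lower number here means that less compound is needed, a higher number that more compound is needed for the effect:
- Compound 1, `FC(F)Oc1ccccc1C1Cc2nccn2C1`: 11 nM
- Compound 2, `COc1ccc(C2Cc3nccn3C2)cc1`: 939 nM
- Compound 3, `c1ccc(C2CCc3nc[nH]c3C2)cc1`: 234 nM; 123 nM; 315 nM (3 entries)

Compound 1 gives the lowest number of the two single values here, with compound 2 standing far higher; compound 3 has several entries rather than one number, and the spread among them, (the several entries of compound 3 in this assay, 234 nM; 123 nM; 315 nM (3 entries)), shows how much repeat measurements of this kind can wander. No pair of these compounds differs in just one place, so no single step has been measured.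

Compound 4, `COCc1ccccc1C1Cc2nccn2C1`, is not yet measured. It differs from compound 1 in one place: methoxymethyl in place of difluoromethoxy on an aromatic carbon. The shared core and the placement of the group on the six-membered aromatic ring are unchanged, so whatever moves in the read-out comes from that exchange alone.

Among the measured compounds shown here, with no measured step to lean on, the expectation is a modest rise in the number, larger than the usual scatter, from compound 1 to compound 4, expressed as a 4.5-fold higher number from compound 1 to compound 4 (0.66 log units; beyond the scatter). Compound 4 is therefore estimated at 50 nM, within a range from 10 nM to 250 nM.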

Compound 4, half-maximal effective concentration: 82 nM
The estimate for compound 4 lay 1.6-fold (0.21 log units) below the measured number; measured number inside the range.
By their numbers in this assay, from the lowest: compound 1; then compound 4; then compound 2.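

The first single change measured at this position, methoxymethyl in place of difluoromethoxy on an aromatic carbon, moves the read-out in this assay, giving a 7.5-fold higher number from compound 1 to compound 4 (0.87 log units; beyond the scatter). So this place on the six-membered aromatic ring is not indifferent to what sits there, even though the two groups match in the simple counts: neither has a hydrogen-bond donor or a net charge, and each has one hydrogen-bond acceptor. The step is also clearly wider than the spread seen when one compound is measured repeatedly: the several entries of compound 3 in this assay, 234 nM; 123 nM; 315 nM (3 entries)

This one step cannot separate the loss of the fluorine atoms from the move of the oxygen away from the aromatic carbon, and it gives no way of telling which of the two matters, if either does alone. From the compounds shown here alone, how an amine, a nitrile or a longer chain would read on the same aromatic carbon remains open, as does whether the same exchange would give a step of similar size on a different core.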